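Ring-carbamate anticonvulsants: ethyl ester homologue of compound 3

The source may hold more compounds than are shown below. What is called first, only, known or untested is meant among the compounds shown, and "the series" means these compounds.

Measured so far in a functional assay on the whole organism for antagonist activity, with Mus musculus as the target, in the maximal electroshock model; on this read-out lower numbers stand for an effect already at smaller amounts and higher numbers for an effect only at larger amounts of compound:
compound 1 `COC(=O)NC1=NC(c2ccccc2)CN1C` gives 107 mg/kg; compound 2 `CCN1CC(c2ccccc2)N=C1NC(=O)OC` gives 66 mg/kg; compound 3 `COC(=O)NC1=NC(c2ccccc2Cl)CN1C` gives 28 mg/kg.

Compound 3 stands lowest of the three, and its steps from compound 1 and compound 2 are both beyond the scatter. The change chloro in place of hydrogen on an aromatic carbon made a 3.8-fold lower number from compound 1 to compound 3 (0.58 log units; beyond the scatter). The change methyl in place of hydrogen on a saturated chain carbon bound to an amine nitrogen in a ring made a 1.6-fold lower number from compound 1 to compound 2 (0.21 log units; within the scatter).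

Compound 4 `CCOC(=O)NC1=NC(c2ccccc2Cl)CN1C` is not yet measured. It differs from compound 3 by methyl in place of hydrogen on a saturated chain carbon bound to an oxygen next to a carbonyl group. This is the same kind of change as that from compound 1 to compound 2, not the same: there the methyl entered on a saturated chain carbon bound to an amine nitrogen in a ring, here on a saturated chain carbon bound to an oxygen next to a carbonyl group. The two cores differ by chloro in place of hydrogen on an aromatic carbon.

Among the compounds with values here, the only comparable step, a 1.6-fold lower number from compound 1 to compound 2 (0.21 log units; within the scatter), lay within the scatter, so a similarly small step is expected in this assay, estimated at a 1.3-fold lower number from compound 3 to compound 4 (0.10 log units; within the scatter). Compound 4 is therefore estimated at 22 mg/kg, with a likely range from 10 mg/kg to 50 mg/kg.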

Compound 4, dose for half-maximal effect: 28 mg/kg
The estimate for compound 4 lay 1.3-fold (0.10 log units) below the measured number; low and high end bracket the measured number.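

In this assay, methyl in place of hydrogen on a saturated chain carbon bound to an oxygen next to a carbonyl group gives no change at the digits printed from compound 3 to compound 4 (within the scatter) and thus no read-out of a gain or loss. Set beside the earlier methyl step, the new step agrees with it:
the same change on two cores in this assay, a 1.6-fold lower number (0.21 log units; within the scatter) from compound 1 to compound 2 and no change at the digits printed (within the scatter) from compound 3 to compound 4, 1.6-fold (0.21 log units) apart, within the scatter of two such steps

On these two cores, then, this small addition stays within the scatter, with or without the chloro group. This does not show that a step carries over at one and the same place, since the methyl enters at a different place in each pair, and a single pair per place gives no general rule.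

The compounds shown leave open how a longer chain, such as propyl or butyl, behaves in the ester. They also leave open whether the methyl on the chain at the ring amine nitrogen gives a similar step on the chloro core.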